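Cyano for methyl on the pendant ring: expected inhibition

The compounds below may be only part of what the source reports. "The series", "measured", "known", "first", "only" and "open" are said of these compounds alone.

Measured so far:
compound 1, `Cc1ccc(-c2nc3cccnc3o2)cc1`: 0%
compound 2, `N#Cc1cccc(-c2nc3ncccc3o2)c1`: 21%

In a functional assay on the whole organism for inhibition, with Rattus norvegicus as the target, at a dose of 30 mg/kg (on this read-out lower numbers stand for less inhibition and higher numbers for more inhibition at the one dose given (going by the name of the read-out)), compound 1 gives 0%, the lower of the two numbers in hand. The nearest number belongs to compound 2, which differs from compound 1 in more than one place and stands higher by an amount beyond the scatter. Going by the values given here, no step between measured compounds that differ in a single place is available, so the size of a one-place change can only be guessed.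

Compound 3, `N#Cc1ccc(-c2nc3cccnc3o2)cc1`, has not yet been measured in this assay. Its change from compound 1 is cyano in place of methyl on an aromatic carbon. Given that compound 2, which also carries a cyano, gives 21% while compound 1 gives 0%, a small rise in inhibition is expected, one that may not clear the scatter. The expected step is a number 10 percentage points higher from compound 1 to compound 3 (within the scatter). For compound 3 the estimate is 10%, with a range from 0% to 30%.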

Compound 3, a percentage reported as inhibition, in the whole organism at one dose (the size of the read-out at that dose, not a potency): 17%
Beside the measured number, compound 3's estimate is 7 percentage points below it; low and high end bracket the measured number.
By their numbers in this assay, from the lowest: compound 1; then compounds 3 and 2 (each within the scatter of the next).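

In this assay, cyano in place of methyl on an aromatic carbon, para to a group of 9 heavy atoms, moves the read-out by a number 17 percentage points higher from compound 1 to compound 3 (beyond the scatter), a modest change. Going by these compounds alone, this is the first single-place step: it shows that this position on the six-membered aromatic ring of carbon only responds to a change of group at the one dose tested, and that the shared core of compound 1 can carry measurable inhibition with a cyano there. Nothing measured on these compounds accounts for the step, so it stands as an observation only.

Going by these compounds, it remains open whether an amine, a carboxylic acid or a longer chain at this position would raise the read-out further, lower it or leave it unchanged. Compound 2 differs from compound 3 in more than one place, so the effect of moving the cyano alone cannot be read from these compounds.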